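Replacing dimethylamino with acetamido: what to expect of compound 4

A few compounds are considered here, and "the series" means these few. Any claim that something is new, unique, unknown or untested is made for them only; others in the source may bear on it.

compound 1 `CCOC(=O)c1c(-c2cccc(OCC)c2)[nH]c2cc(OC)ccc2c1=O`: > 22000 nM
compound 2 `CCOC(=O)c1c(-c2cccc(OCc3ccccc3)c2)[nH]c2cc(OC)ccc2c1=O`: > 22000 nM
compound 3 `CCOC(=O)c1c(-c2cccc(N(C)C)c2)[nH]c2cc(OC)ccc2c1=O`: > 22000 nM

All three values come from an ADME assay on HEK293 cells (Homo sapiens) for cytotoxicity, read by luminescence, with a stated time of 72 h; on this read-out lower numbers stand for an effect already at smaller amounts and higher numbers for an effect only at larger amounts of compound. Compound 3 reads > 22000 nM, which is a limit of the assay and not a number. Compound 4 `CCOC(=O)c1c(-c2cccc(NC(C)=O)c2)[nH]c2cc(OC)ccc2c1=O` has not been measured yet. It differs from compound 3 by one change, acetamido in place of dimethylamino on an aromatic carbon.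

The measured steps closest to this change are a step that the two limits leave unreadable from compound 1 to compound 3 and a step that the two limits leave unreadable from compound 2 to compound 3, and each swaps the group on that aromatic carbon. Neither has a readable size, and the same holds for a step that the two limits leave unreadable from compound 1 to compound 2. In this assay, no step beyond the scatter is expected. This expectation rests on compound 3 sitting with compound 1 and compound 2 at the limit of > 22000 nM in this assay, at which 3 of the 3 values shown sit. The expected change is a step that the limit leaves unreadable from compound 3 to compound 4, and another limit is the most likely report. For compound 4 the estimated value is 30000 nM, with an expected range from 12000 nM to 60000 nM.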

Compound 4, half-maximal effective concentration: > 22000 nM
Compound 4: no number, only a limit; the forecaster's own chance of this, stated with the estimate: 85%; the middle value does not contradict the limit.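

In this assay compound 4 gives > 22000 nM, which is a limit of the assay and not a number. Its steps to compound 1, compound 2 and compound 3 cannot be read, as all four compounds share that limit: the limit of > 22000 nM in this assay, at which 4 of the 4 values shown sit.

The compounds shown leave open whether any change to the shared core would give a readable value in this assay.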